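Series notes: the step from compound 2 to compound 3

A few compounds are considered here, and "the series" means these few. Any claim that something is new, unique, unknown or untested is made for them only; others in the source may bear on it.

Compound 1 `CC(C)N(C(=O)c1ccc(-c2ccc(Cl)cc2)o1)c1ccc(N2CCNCC2)cc1` carries isopropyl on the amide-type nitrogen. In an ADME assay on SW1353 cells (Homo sapiens) for cytotoxicity, read by a luciferase reporter, with a stated time of 30 min (on this read-out lower numbers stand for higher toxicity in this test and higher numbers for lower toxicity in this test), compound 1 gives > 20000 nM, which is a limit of the assay and not a number (the limit of > 20000 nM in this assay, at which 1 of the 2 values shown sits). Compound 2 `CCCCN(C(=O)c1ccc(-c2ccc(Cl)cc2)o1)c1ccc(N2CCNCC2)cc1` carries butyl in the same position; in this assay compound 2 gives 19000 nM, the only number shown in this series. The step of an at least 1.0-fold lower number from compound 1 to compound 2 (0.02 log units; that floor lies within the scatter) sits at the floor, within the scatter. Compound 3 `Cn1ccnc1CN(C(=O)c1ccc(-c2ccc(Cl)cc2)o1)c1ccc(N2CCNCC2)cc1` is compound 2 with 1-methyl-1H-imidazol-2-yl in place of propyl on a saturated chain carbon bound to an amide-type nitrogen. Among the compounds with values here, no measured step puts an aromatic ring in this position, and the only change made so far on the amide-type nitrogen, an at least 1.0-fold lower number from compound 1 to compound 2 (0.02 log units; that floor lies within the scatter), stayed within the scatter, so no step beyond the scatter is expected here. Compound 3 is therefore expected to give 19000 nM, between 7000 nM and 45000 nM, and the expected step of no change at the digits printed from compound 2 to compound 3 (within the scatter) lies within the scatter. The reading for compound 3 in this assay is awaited.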

Compound 3, half-maximal cytotoxic concentration: > 20000 nM
Compound 3: no number, only a limit; the forecaster's own chance of this, stated with the estimate: 45%; middle value at least 1.0-fold (0.02 log units) away from the limit.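

The step to the first aromatic ring in this position, on a saturated chain carbon bound to an amide-type nitrogen, reads an at least 1.0-fold higher number from compound 2 to compound 3 (0.02 log units; that floor lies within the scatter), so in this assay replacing propyl with 1-methyl-1H-imidazol-2-yl gives no step beyond the scatter. The step between the two limits, from compound 1 to compound 3, cannot be read. Most of the series now reads as a limit and not as a number: the limit of > 20000 nM in this assay, at which 2 of the 3 values shown sit.

As far as these compounds go, it remains open whether any group on this nitrogen, such as a chain ending in a carboxylic acid or a dimethylamino group, would give a step beyond the scatter. From the compounds shown here alone, how far the true value of compound 3 lies from that of compound 2 also stays open.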